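The compounds below may be only part of what the source reports. "The series", "measured", "known", "first", "only" and "open" are said of these compounds alone.

Compound 1 `C=C1C[C@]23C[C@@]1(O)CC[C@H]2c1ccc(OS(=O)(=O)c2ccc(C)cc2)c(C)c1[C@@H]3Cn1cc(-c2ccc(Br)cc2)nn1` carries a 4-(4-bromophenyl)-1H-1,2,3-triazol-1-yl group on its core. In a functional assay on HL-60 cells (Homo sapiens) for cytotoxicity, read by MTT assay, with a stated time of 4 days (a lower number here means a stronger inhibitor, a higher number a weaker inhibitor), compound 1 gives only a limit of the assay, > 20000 nM. Compound 2 `C=C1C[C@]23C[C@@]1(O)CC[C@H]2c1ccc(OS(=O)(=O)c2ccc(C)cc2)c(C)c1[C@@H]3Cn1cc(-c2ccccc2)nn1` differs from compound 1 by one change, (hydrogen in place of bromo on an aromatic carbon). In this assay compound 2 likewise gives only a limit, > 20000 nM. The step that the two limits leave unreadable from compound 1 to compound 2 therefore has no readable size, because of the limit of > 20000 nM in this assay, at which 2 of the 3 values shown sit.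

Compound 3 `C=C1C[C@]23C[C@@]1(O)CC[C@H]2c1cc(Br)c(O)c(C)c1[C@@H]3Cn1cc(-c2ccc(Cl)cc2)nn1` rests on a different core; the difference between the two cores is not broken down here. In this assay, for the measured compounds named here, compound 3 gives 5590 nM, the only actual number among the three measured compounds.

Compound 4 `C=C1C[C@]23C[C@@]1(O)CC[C@H]2c1ccc(O)c(C)c1[C@@H]3Cn1cc(-c2ccc(Cl)cc2)nn1` has not yet been measured. It differs from compound 3 by hydrogen in place of bromo on an aromatic carbon. Going by the values given here, this is the same kind of change as the one from compound 1 to compound 2, but the place is not the same: in compound 1 the bromo sits on a six-membered aromatic ring of carbon only, para to a large group, whereas in compound 3 it sits on a ring that is part of a fused or bridged system of four rings, ortho to a hydroxy group, meta to a fused ring, meta to a methyl group and para to a fused ring. The earlier step offers no size to lean on, so the expectation rests on compound 3 alone, whose value 5590 nM is taken as the starting point. The step of a 1.6-fold higher number from compound 3 to compound 4 (0.21 log units; within the scatter) is expected to be modest. Compound 4 is expected to give about 9000 nM, somewhere between 3000 nM and 20000 nM.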

Compound 4, half-maximal inhibitory concentration: > 20000 nM
Compound 4: no number, only a limit; the forecaster's own chance of this, stated with the estimate: 30%; middle value at least 2.2-fold (0.34 log units) from the limit.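

In this assay, replacing the bromo ortho to a hydroxy group in compound 3 with hydrogen gives an at least 3.5-fold higher number from compound 3 to compound 4 (0.55 log units; beyond the scatter), so on this core the loss of that one atom goes with a clear weakening. Compound 4 gives > 20000 nM, which is a limit of the assay and not a number. The same kind of change on the other core, between compound 1 and compound 2, cannot be read, so this pair shows an effect on one core only and does not show that the change behaves alike on both, nor how large the step truly is, because the values on that side stop at the same edge: the limit of > 20000 nM in this assay, at which 3 of the 4 values shown sit.

The compounds shown leave open what a group other than bromo or hydrogen at this place on the ring, such as a methoxy group or an amine, would give in this assay. Also open is whether the bromo would matter as much if the neighbouring hydroxy group were replaced by another group, such as a carboxylic acid, since only one pair on this core is shown.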